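The source may report more compounds than this note shows. Statements on the series, on what has been measured and on what is new or still open speak of the compounds shown alone.

Compound 1 `CC(=O)NC[C@H]1CN(c2ccc(OC[C@@H](O)CNc3ccc(C#N)cc3)c(F)c2)C(=O)O1` gives 2.12 in a physicochemical assay for lipophilicity, read by HPLC (on this read-out higher numbers stand for higher lipophilicity and lower numbers for lower lipophilicity), the second highest of the three numbers shown. Among the measured compounds shown here, compound 2 `CC(=O)NC[C@H]1CN(c2ccc(OC[C@H](O)CNc3ccc(C#N)cc3)c(F)c2)C(=O)O1` gives 1.29 in this assay, and the step of a number 0.83 log units lower from compound 1 to compound 2 (beyond the scatter) is the only measured step between neighbours; it rests on (the fact that compounds 1 and 2 differ only in the configuration as drawn). Compound 3 `CC(=O)NC[C@H]1CN(c2ccc(OC[C@@H](O)CNc3cc(C(F)(F)F)cc(C(F)(F)F)c3)c(F)c2)C(=O)O1` gives 3.1 in this assay. Compound 4 `CC(=O)NC[C@H]1CN(c2ccc(OC[C@@H](O)CNc3ccncc3)c(F)c2)C(=O)O1` differs from compound 1 by pyridin-4-yl in place of 4-cyanophenyl on an amine nitrogen. For the measured compounds named here, no measured step concerns this exchange, and the step between compounds 1 and 2 touches configuration only, so it gives no guide to its size. Compound 4 is nevertheless expected to read lower, by a step of a number 1.02 log units lower from compound 1 to compound 4 (beyond the scatter). For compound 4 the estimated value in this assay is 1.1, within a range from 0.5 to 1.7.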

Compound 4, partition coefficient: -0.04
Beside the measured number, compound 4's estimate is 1.14 log units above it; the measured number lies below the stated range.
By their numbers in this assay, from the lowest: compound 4; then compound 2; then compound 1; then compound 3.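

In this assay the exchange of 4-cyanophenyl for pyridin-4-yl on this amine nitrogen gives a number 2.16 log units lower from compound 1 to compound 4 (beyond the scatter) and is the larger of the two steps, the other being a number 0.83 log units lower from compound 1 to compound 2 (beyond the scatter) in configuration alone. The group on this nitrogen thus spans a wide range, with compound 3 at 3.1 and compound 4 at -0.04 at the two ends. Among the compounds shown here, nothing given here bears on why the exchange moves the number so far. A plain phenyl or a pyridin-3-yl group on the same nitrogen would show how the step divides between the nitrile and the ring nitrogen. On these data alone, whether the step holds in the other configuration also stays open.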